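The source may hold more compounds than are shown below. What is called first, only, known or untested is meant among the compounds shown, and "the series" means these compounds.

In a functional assay on HL-60 cells (Homo sapiens) for inhibition, read by MTT assay, with a stated time of 72 h (a lower number here means a stronger inhibitor, a higher number a weaker inhibitor), compound 2 `Cc1nc(-c2ccc(F)cc2)c(C(=O)N2CCN(c3cccc(Cl)c3)CC2)o1` gives 40.1 nM, level within the scatter with compound 3 `Cc1nc(-c2cccc(F)c2)c(C(=O)N2CCN(c3cccc(Cl)c3)CC2)o1` at 33.7 nM, while compound 1 `CCc1nc(-c2ccccc2F)c(C(=O)N2CCN(c3cccc(Cl)c3)CC2)o1` gives a higher 139 nM. Compound 4 `CCc1nc(-c2ccc(F)cc2)c(C(=O)N2CCN(c3cccc(Cl)c3)CC2)o1` takes compound 2 from methyl to ethyl: methyl in place of hydrogen on a saturated chain carbon bound to an aromatic carbon. Among the measured compounds shown here, no measured step isolates this change. For the measured compounds named here, the only step available, a 1.2-fold lower number from compound 2 to compound 3 (0.08 log units; within the scatter), concerns the fluorine on the phenyl and leaves the chain untouched. Compound 1 at 139 nM also bears ethyl, but its fluorophenyl differs too, so it offers only a weak hint towards a higher number. A modest rise in this assay is therefore expected, with the expected size being a 1.6-fold higher number from compound 2 to compound 4 (0.21 log units; within the scatter). For compound 4 the estimate is 65 nM, with an expected range of 28 nM to 150 nM.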

Compound 4, half-maximal inhibitory concentration: 169 nM
Compound 4: the middle estimate sits 2.6-fold (0.41 log units) below what was measured, and the stated range ends below it.
By their numbers in this assay, from the lowest: compounds 3 and 2 (each within the scatter of the next); then compounds 1 and 4 (each within the scatter of the next).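

In this assay, among the compounds shown here, the chain position is sensitive to this small change: methyl in place of hydrogen gives a 4.2-fold higher number from compound 2 to compound 4 (0.62 log units; beyond the scatter), the first isolated reading of this change. With ethyl present, 4-fluorophenyl in place of 2-fluorophenyl gives a 1.2-fold higher number from compound 1 to compound 4 (0.08 log units; within the scatter), so these two ethyl compounds stand level. No available evidence accounts for the rise on going from methyl to ethyl.

From the compounds shown here alone, whether a longer chain such as propyl, or a branched one such as isopropyl, extends this rise remains open. So does the effect of a hydroxyl or an amine on the chain.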